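A few compounds are considered here, and "the series" means these few. Any claim that something is new, unique, unknown or untested is made for them only; others in the source may bear on it.

Measured compounds:

compound 1 `Cc1ccccc1OC1CCN(c2ccc(-n3ccnc3)nn2)CC1`, in an assay on microsomes from liver for inhibition of acyl-CoA desaturase 1 (Rattus norvegicus) (a higher number here means a weaker inhibitor, a lower number a stronger inhibitor), compound 1 gives 39 nM
compound 2 `CC(=O)c1ccccc1OC1CCN(c2ccc(-n3ccnc3)nn2)CC1`, in this assay compound 2 gives 34 nM

Going by the values given here, compound 2 stands at the lower of the two numbers in this assay, but the gap to compound 1, the only other measured compound, is a 1.1-fold lower number from compound 1 to compound 2 (0.06 log units; within the scatter), so the two cannot be told apart on these data.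

Compound 3 `c1cn(-c2ccc(N3CCC(Oc4ccc5c(c4)CCC5)CC3)nn2)cn1` is the next compound in this series. It differs from compound 2 in one place: 2,3-dihydro-1H-inden-5-yl in place of 2-acetylphenyl on an oxygen on a saturated carbon.

Among the compounds with values here, only one measured step exists, acetyl in place of methyl on an aromatic carbon, and it stayed within the scatter. That step concerns a small group on the aromatic ring, whereas the change to compound 3 swaps out the whole aryl group on the ether oxygen, so it offers little guidance for the present case. Within the data shown here, with no measured step of comparable kind, the expectation for compound 3 rests on the number for compound 2 alone, and the step is expected to be a 1.0-fold higher number from compound 2 to compound 3 (0.01 log units; within the scatter), that is, none beyond the scatter.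

Compound 3 is therefore estimated at 35 nM in this assay, with a range from 12 nM to 110 nM.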

Compound 3, half-maximal inhibitory concentration: 62 nM
For compound 3 the middle estimate is 1.8-fold (0.25 log units) below the measured one; the measured number falls inside the stated range.
By their numbers in this assay, from the lowest: compounds 2, 1 and 3 (each within the scatter of the next).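

Swapping the entire aryl group on an oxygen on a saturated carbon, not just a small group on the aromatic ring, still gives only a 1.8-fold higher number from compound 2 to compound 3 (0.26 log units; within the scatter) in this assay and a 1.6-fold higher number from compound 1 to compound 3 (0.20 log units; within the scatter) in the same assay. On these data, then, 2,3-dihydro-1H-inden-5-yl, with its five-membered non-aromatic ring of carbon only and no hydrogen-bond acceptor, cannot be told apart at this position from 2-acetylphenyl, which carries a hydrogen-bond acceptor and a double bond outside aromatic rings, or from 2-methylphenyl. Nothing measured here speaks to the reason for this result.

The compounds shown leave open whether any group at this position moves the number beyond the scatter, since all three are aryl groups that span only a narrow set of changes. A saturated ring such as cyclohexyl in place of the aryl group, or an aryl group carrying a carboxylic acid or an amine, would show whether the aromatic ring is needed and how far the position can be changed.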